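The compounds below may be only part of what the source reports. "The series", "measured", "known", "first", "only" and "open" are said of these compounds alone.

Compound 1 `Oc1cccc(-c2cc(-c3ccccc3C(F)(F)F)cc(-c3ccccc3O)n2)c1` is the starting point. In a functional assay on T47D cells (Homo sapiens) for inhibition (on this read-out lower numbers stand for stronger inhibition and higher numbers for weaker inhibition), compound 1 gives 5680 nM. Compound 2 `Oc1cccc(-c2cc(-c3ccccc3C(F)(F)F)cc(-c3cccc(O)c3)n2)c1` keeps the same atoms joined differently: the change (3-hydroxyphenyl in place of 2-hydroxyphenyl on an aromatic carbon). In this assay compound 2 gives 4350 nM, and the step is a 1.3-fold lower number from compound 1 to compound 2 (0.12 log units; within the scatter), so the two numbers cannot be told apart.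

Compound 3 `Oc1ccccc1-c1cc(-c2cccc(OC(F)(F)F)c2)cc(-c2ccccc2O)n1` carries a different core from compound 1, and the difference between the two cores is not broken down here. In this assay compound 3 gives only a limit of the assay, > 50000 nM, not a number, and this is the limit of > 50000 nM in this assay, at which 1 of the 3 values shown sits.

Compound 4 `Oc1cccc(-c2cc(-c3cccc(OC(F)(F)F)c3)cc(-c3ccccc3O)n2)c1` has not yet been measured. It is made from compound 3 by the change (3-hydroxyphenyl in place of 2-hydroxyphenyl on an aromatic carbon). Within the data shown here, this is the same kind of change as the one from compound 1 to compound 2, but the surroundings differ: there the place was meta to a 2-(trifluoromethyl)phenyl group and meta to a 3-hydroxyphenyl group, here it is meta to a 2-hydroxyphenyl group and meta to a large group.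

The step from compound 3 to compound 4 is expected to be about a number no higher from compound 3 to compound 4 (the limit leaves the size open), resting on compound 1 and compound 2, whose step was a 1.3-fold lower number from compound 1 to compound 2 (0.12 log units; within the scatter). Compound 4 is therefore estimated at 50000 nM in this assay, with an expected range from 20000 nM to 150000 nM, and most likely the assay again reports only a limit.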

Compound 4, half-maximal inhibitory concentration: 5390 nM
For compound 4 the middle estimate is 9.3-fold (0.97 log units) above the measured one; measured number outside the range, below it.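

In this assay, putting a 3-hydroxyphenyl group in place of a 2-hydroxyphenyl group gives an at least 9.2-fold lower number from compound 3 to compound 4 (0.96 log units; beyond the scatter), so on this core the change has a clear effect. The same swap therefore does not carry over with the same size from one core to the other: the same change on two cores in this assay, a 1.3-fold lower number (0.12 log units; within the scatter) from compound 1 to compound 2 and an at least 9.2-fold lower number (0.96 log units; beyond the scatter) from compound 3 to compound 4, at least 7.1-fold (0.85 log units) apart, beyond the scatter of two such steps
For compound 3 the value > 50000 nM is a limit of the assay and not a number, so the true size of this step stays unknown, and two pairs show only that the result of the change differed between these two cores, not why it differed or what it would do on a third core.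

The two steps also do not start from the same point, since compound 1 already carries one 3-hydroxyphenyl group while compound 3 carries two 2-hydroxyphenyl groups, which leaves open how the core of compound 1 with two 2-hydroxyphenyl groups and the core of compound 3 with two 3-hydroxyphenyl groups would read. The compounds shown also leave open what happens when an amine or a carboxylic acid takes the place of the hydroxy group on these rings.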